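The source may hold more compounds than are shown below. What is called first, only, known or untested is meant among the compounds shown, and "the series" means these compounds.

Compound 2 `COc1ccc(C(F)(F)F)cc1Nc1cc(NC(=O)Nc2c(Cl)cccc2Cl)ncn1` gives 89% in a functional assay on PC-9 cells (Homo sapiens) for inhibition, read by MTT assay, with a stated time of 48 h, tested at 10 uM (a lower number here means less inhibition, a higher number more inhibition at the concentration tested (going by the name of the read-out)), the highest of the two numbers at hand; its nearest neighbour is compound 1 `COc1ccc(F)cc1Nc1cc(NC(=O)Nc2c(Cl)cccc2Cl)ncn1`, which gives 85.5% in this assay, and the step of a number 3.5 percentage points higher from compound 1 to compound 2 (within the scatter) lies within the scatter. Compound 3 `COc1ccc(OC)c(Nc2cc(NC(=O)Nc3c(Cl)cccc3Cl)ncn2)c1` differs from compound 2 by methoxy in place of trifluoromethyl on an aromatic carbon. Among the compounds with values here, the only measured step that bears on this is the one at the same aromatic carbon, a number 3.5 percentage points higher from compound 1 to compound 2 (within the scatter), where one small group replaced another without a change beyond the scatter. That offers no ground for expecting a move in either direction here, so compound 3 is expected to show a step of a number 4 percentage points lower from compound 2 to compound 3 (within the scatter), that is, none beyond the scatter. The estimate for compound 3 in this assay is therefore 85%, with a range from 70% to 95%.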

Compound 3, a percentage reported as inhibition, at one concentration (the size of the read-out at that concentration, not a potency): 95%
Beside the measured number, compound 3's estimate is 10 percentage points below it; the measured number falls inside the stated range.
By their numbers in this assay, from the lowest: compounds 1, 2 and 3 (each within the scatter of the next).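

At this aromatic carbon, meta to a large group and para to a methoxy group, methoxy in place of trifluoromethyl comes with a number 6 percentage points higher from compound 2 to compound 3 (within the scatter) in this assay, and methoxy in place of fluoro comes with a number 9.5 percentage points higher from compound 1 to compound 3 (within the scatter) for the same position. The earlier pair showed only that fluoro and trifluoromethyl could be exchanged here; the new steps extend this to methoxy, which carries a hydrogen-bond acceptor where trifluoromethyl has none, with no change beyond the scatter. Nothing at hand explains why the numbers stay so close.

Going by these compounds, whether the number would be higher, lower or level with an amine, a carboxylic acid or a longer chain such as butoxy at this carbon remains open. On these data alone, because each number is the size of the read-out at one concentration, it also remains open whether these three compounds differ in potency.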